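This account rests on a few compounds, and the source may have more. Where it says the series, first, only, none or still open, it means among the compounds named here.

Measured compounds in a functional assay for inhibition, with Homo sapiens as the target; a lower number here means a stronger inhibitor, a higher number a weaker inhibitor:
compound 1 `CCCc1nc(C)c2c(C)nn(C)c(=O)n12`: > 48000 nM, a limit of the assay.
compound 2 `CCCc1nc(C)c2c(C)nn(CC)c(=O)n12`: > 48000 nM, a limit of the assay.
compound 3 `CCc1nc(C)c2cnnc(O)n12`: > 48000 nM, a limit of the assay.

All three values rest at the limit of > 48000 nM in this assay, at which 3 of the 3 values shown sit, so no number is known for any of them. From compound 2 to compound 1 the change is hydrogen in place of methyl on a saturated chain carbon bound to an aromatic nitrogen, and the step that the two limits leave unreadable from compound 2 to compound 1 stays unreadable with both ends at the limit. The difference between the cores of compound 2 and compound 3 is not broken down here. Compound 4 `Cc1nc(C)n2c(O)nncc12` is not yet measured and differs from compound 3 by hydrogen in place of methyl on a saturated chain carbon bound to an aromatic carbon. This is the same kind of change as from compound 2 to compound 1, but the saturated chain carbon is bound to an aromatic carbon rather than to an aromatic nitrogen. Because every measured value rests at the limit of > 48000 nM in this assay, at which 3 of the 3 values shown sit, compound 4 is expected to give about 70000 nM in this assay, between 25000 nM and 250000 nM, most likely again only as a limit. The expected step is a step that the limit leaves unreadable from compound 3 to compound 4.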

Compound 4, half-maximal inhibitory concentration: > 48000 nM
Compound 4: a limit, no number; the forecaster's own chance of this, stated with the estimate: 85%; the middle value lies beyond the limit too.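

No step can be read from compound 3 to compound 4, as both rest at a limit in this assay: the limit of > 48000 nM in this assay, at which 4 of the 4 values shown sit.

The compounds shown leave open which change to the shared core, if any, would give a readable number in this assay.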